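A few compounds are considered here, and "the series" means these few. Any claim that something is new, unique, unknown or untested is made for them only; others in the source may bear on it.

Measured so far:
compound 1 `CC1=NN(c2cccc(Cl)c2)C(=O)C12C=CC(=O)C=C2c1ccc(C)cc1` — 2400 nM
compound 2 `CC1=NN(c2ccc(Cl)cc2)C(=O)C12C=CC(=O)C=C2c1cccc(C)c1` — 13300 nM

Both numbers come from a functional assay on HCT-116 cells (Homo sapiens) for antiproliferative activity, read by CCK-8 assay, with a stated time of 72 h; on this read-out lower numbers stand for stronger inhibition and higher numbers for weaker inhibition. Compound 1 gives the lowest of the two numbers shown; compound 2 gives a higher number, and the gap between the two lies beyond the usual scatter of repeated measurements. Within the data shown here, compound 1 and compound 2 differ from each other in more than one place, so no single step is drawn from that pair, and their gap cannot be read as the effect of any one change.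

Compound 3 `CC1=NN(c2ccccc2)C(=O)C12C=CC(=O)C=C2c1ccc(C)cc1` is not yet measured in this assay. It differs from compound 1 in one place: hydrogen in place of chloro on an aromatic carbon. Hydrogen takes the place of chloro on an aromatic carbon of a six-membered aromatic ring of carbon only, meta to a large group. Among the measured compounds shown here, no measured pair shows this same change, so its size is not known from the data at hand.

The expectation is a small rise in the number, near the edge of the scatter: in this assay the expected step is a 2.1-fold higher number from compound 1 to compound 3 (0.32 log units; beyond the scatter). Compound 3 is estimated to give 5000 nM, with a range from 1500 nM to 15000 nM.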

Compound 3, half-maximal inhibitory concentration: 27100 nM
For compound 3 the middle estimate is 5.4-fold (0.73 log units) below the measured one, outside the stated range (above it).
By their numbers in this assay, from the lowest: compound 1; then compound 2; then compound 3.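

In this assay, hydrogen in place of chloro on an aromatic carbon, meta to a large group, gives an 11-fold higher number from compound 1 to compound 3 (1.05 log units; beyond the scatter), a large step that lies beyond the scatter. This position is therefore not a silent one in the setting of compound 1: a single chlorine atom on the six-membered aromatic ring accounts for a large part of the activity, and the change from 3-chlorophenyl to phenyl gives up most of it. No measured property of these compounds bears on this result, so the size of the step stands without an explanation.

Still open, on these data alone, is whether the activity is tied to chloro itself or would be kept by another group in the same place, such as fluoro, methoxy, an amine or a carboxylic acid. As far as these compounds go, this step also rests on a single pair, so it is unknown whether removing chloro would cost as much in a compound with the other substitution pattern of compound 2, which differs from compound 1 in more than one place.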